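Shortening the chain: from compound 1 to compound 4

The source may hold more compounds than are shown below. What is called first, only, known or untested is meant among the compounds shown, and "the series" means these compounds.

Measured so far:
compound 1, `CCCCC(C#CC(=O)OC)O/C=C/C(=O)OC`, 240 nM
compound 2, `C#CC(O/C=C/C(=O)OC)c1ccccc1`, 31000 nM
compound 3, `CCOC(=O)C#CCO/C=C/C(=O)OC`, 1800 nM

The three measured compounds were tested in a functional assay on SW1573 cells (Homo sapiens) for antiproliferative activity, read by sulforhodamine B assay, with a stated time of 48 h; a lower number here means a stronger inhibitor of growth, a higher number a weaker inhibitor of growth. Compound 1 gives the lowest number of the three: compound 3 gives a number that is higher by more than the scatter, and compound 2 gives a number that lies further still. Compound 1 is therefore the strongest inhibitor of growth among the three in this assay.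

Compound 4, `COC(=O)C#CC(O/C=C/C(=O)OC)C(C)C`, has not yet been measured. It differs from compound 1 in one place: isopropyl in place of butyl on a saturated chain carbon bound to an oxygen on an unsaturated carbon and a triple-bonded carbon. Within the data shown here, no pair of measured compounds differs in this way, so there is no direct guide to the size of this step. Among the measured compounds shown here, the only hint comes from compound 3, which carries no alkyl group at that carbon and gives 1800 nM, well above compound 1; the isopropyl group of compound 4 stands between those two cases. A modest rise in the number is expected, and the step from compound 1 to compound 4 is estimated at a 2.1-fold higher number from compound 1 to compound 4 (0.32 log units; beyond the scatter), close to the edge of the scatter. Compound 4 is therefore expected to give about 500 nM in this assay, within a range from 150 nM to 1600 nM.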

Compound 4, concentration for 50% growth inhibition: 750 nM
Beside the measured number, compound 4's estimate is 1.5-fold (0.18 log units) below it, and the stated range covers the measured number.
By their numbers in this assay, from the lowest: compound 1; then compound 4; then compound 3; then compound 2.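

In this assay, isopropyl in place of butyl on a saturated chain carbon bound to an oxygen on an unsaturated carbon and a triple-bonded carbon gives a 3.1-fold higher number from compound 1 to compound 4 (0.49 log units; beyond the scatter) and so a modest step that lies beyond the scatter. Among these compounds, this is the first pair in the set that differs in one place only, and it gives the first direct reading of this position: the number responds to the alkyl group there, yet the change from butyl to isopropyl costs only a modest part of the growth inhibition seen with compound 1. Nothing measured for these compounds accounts for the size of this step.

This single pair changes chain length and branching together, so the two cannot be told apart, and a straight propyl chain at the same carbon would be needed to separate them. On these data alone, how a longer chain such as hexyl, or a chain ending in an amine or a carboxylic acid, would behave at this carbon also remains open.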